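A fluoro group on the terminal ring of compound 3

The compounds below may be only part of what the source reports. "The series", "measured", "known", "first", "only" and "open" are said of these compounds alone.

Compound 1 `Cc1ccc2[nH]c(-c3ccc(-c4ccc(-c5ccc(N(C)C)cc5)cc4)cc3)nc2c1`: 3510 nM
Compound 2 `COc1ccc(-c2ccc(-c3ccc(-c4nc5cc(C)ccc5[nH]4)cc3)cc2)cc1OC`: 2100 nM
Compound 3 `Cc1ccc2[nH]c(-c3ccc(-c4ccc(-c5ccccc5)cc4)cc3)nc2c1`: 3630 nM

These three compounds were tested in a functional assay on A549 cells (Homo sapiens) for inhibition, read by sulforhodamine B assay; a lower number here means a stronger inhibitor of growth, a higher number a weaker inhibitor of growth. Compound 3, which carries no substituent on its terminal ring, gives 3630 nM, and this value lies within the scatter of the values for the other two compounds. The next compound, compound 4 `Cc1ccc2[nH]c(-c3ccc(-c4ccc(-c5ccc(F)cc5)cc4)cc3)nc2c1`, differs from compound 3 at a single place: fluoro in place of hydrogen on an aromatic carbon. This is fluoro in place of hydrogen on an aromatic carbon, para to a large group.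

Within the data shown here, no fluoro compound has been measured yet, so the evidence is indirect. Among the measured compounds shown here, two measured steps bear on the change. The closer one concerns the same carbon, with hydrogen in place of dimethylamino: a 1.0-fold higher number from compound 1 to compound 3 (0.01 log units; within the scatter). The other exchanges the whole terminal ring, with phenyl in place of 3,4-dimethoxyphenyl: a 1.7-fold higher number from compound 2 to compound 3 (0.24 log units; within the scatter). Neither step leaves the scatter, although both involve larger groups than fluoro. A step beyond the scatter is therefore not expected here. The expected result is a 1.2-fold lower number from compound 3 to compound 4 (0.08 log units; within the scatter), a change that would stay within the scatter. Compound 4 is estimated at 3000 nM, with an expected range from 1500 nM to 6000 nM.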

Compound 4, concentration for 50% growth inhibition: 6030 nM
For compound 4 the middle estimate is 2.0-fold (0.30 log units) below the measured one, and the stated range ends below it.
By their numbers in this assay, from the lowest: compounds 2, 1, 3 and 4 (each within the scatter of the next, the first and the last beyond it).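

In this assay, fluoro in place of hydrogen on this aromatic carbon, para to a large group, stays within the scatter (a 1.7-fold higher number from compound 3 to compound 4 (0.22 log units; within the scatter)), and so does fluoro in place of dimethylamino (a 1.7-fold higher number from compound 1 to compound 4 (0.24 log units; within the scatter)), so hydrogen, dimethylamino and fluoro at this carbon cannot be told apart here. The exchange of the whole terminal ring, 4-fluorophenyl in place of 3,4-dimethoxyphenyl, is however the only step among these four compounds that lies beyond the scatter, and it is modest in size (a 2.9-fold higher number from compound 2 to compound 4 (0.46 log units; beyond the scatter)), whereas the step with plain phenyl in place of 3,4-dimethoxyphenyl stayed within it. Nothing given here accounts for this gap.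

The compounds shown leave open whether a single methoxy group on this carbon would be enough to give a step of the same size from compound 4, or whether both methoxy groups of compound 2 are needed. They also leave open whether a carboxylic acid, a primary amine or a nitrile on this carbon would produce a step beyond the scatter from compound 3.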